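The source may hold more compounds than are shown below. What is called first, only, known or untested is meant among the compounds shown, and "the series" means these compounds.

Measured compounds and values in an assay for inhibition of tRNA (cytosine(38)-C(5))-methyltransferase (Homo sapiens), with a stated time of 5 min, tested at 100 uM; a higher number here means more inhibition at the concentration tested (going by the name of the read-out), a lower number less inhibition:
- compound 3 `CC(C)N(CC[C@H](N)C(=O)O)C[C@H]1O[C@@H](n2cnc3c(N)ncnc32)[C@H](O)[C@@H]1O` — 44%
- compound 1 `Nc1ncnc2c1ncn2[C@@H]1O[C@H](CSCCCC(=O)O)[C@@H](O)[C@H]1O` — no result reported
- compound 2 `Nc1ncnc2c1ncn2[C@@H]1O[C@H](CNC(=O)CC[C@H](N)C(=O)O)[C@@H](O)[C@H]1O` — no result reported

For the measured compounds named here, compound 3 carries the only number. In this assay compound 3 gives 44%, a partial inhibition at the single test concentration, with nothing from compound 1 or compound 2 to set it against. Its standing is therefore that of a lone reference point rather than a ranked member of a set.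

Compound 4 `C#CCN(CC[C@H](N)C(=O)O)C[C@H]1O[C@@H](n2cnc3c(N)ncnc32)[C@H](O)[C@@H]1O` has not been measured. It differs from compound 3 at one position only: propargyl in place of isopropyl on an amine nitrogen. The amine nitrogen keeps both of its saturated chain carbon neighbours and the remainder of the molecule, including the shared core and the amino acid chain, is unchanged.

Going by the values given here, no step between measured compounds is available to calibrate this exchange. With the substituent kept at the same heavy-atom count and without any change in donor or acceptor count or in charge, the expected step from compound 3 to compound 4 is small, a number 2 percentage points lower from compound 3 to compound 4 (within the scatter), and is not expected to exceed the usual scatter in either direction. Compound 4 is accordingly estimated at 42%, with a range from 22% to 62%.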

Compound 4, a percentage reported as inhibition, at one concentration (the size of the read-out at that concentration, not a potency): 72.2%
The estimate for compound 4 lay 30.2 percentage points below the measured number; the measured number lies above the stated range.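

Propargyl in place of isopropyl on an amine nitrogen gives a number 28.2 percentage points higher from compound 3 to compound 4 (beyond the scatter) in this assay, the first sign that this position responds to the choice of substituent, which compound 3 alone could not show. The two groups match in heavy atoms, carbon count, hydrogen-bond donors, hydrogen-bond acceptors and net charge, so these counts do not separate them, and the one counted feature that differs is the triple bond outside aromatic rings that propargyl brings. Nothing at hand bears on what lies behind the step, which remains an observation on a single pair.

Still open, going by these compounds, is whether the triple bond itself matters: allyl or n-propyl on the same amine nitrogen would show whether the read-out tracks the triple bond or simply the loss of isopropyl, and a butynyl group, with its longer chain, would test how far the triple bond can sit from that nitrogen. Also open, on these data alone, is how the step would look as a potency, since the read-out here reports inhibition at one concentration only.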